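The compounds below may be only part of what the source reports. "The series", "measured", "known", "first", "only" and "open" are said of these compounds alone.

Compound 1 `CCCCCNC(=O)[C@H]1O[C@@H](n2cnc3c(N)ncnc32)[C@H](O)[C@@H]1O` carries a pentyl group on its amide nitrogen, and in an assay on cell membranes for binding affinity to 2-oxoglutarate receptor 1 (Rattus norvegicus), read by radioligand binding (a lower number here means a stronger inhibitor, a higher number a weaker inhibitor), compound 1 gives 12 nM. Compound 2 `CC(C)(C)NC(=O)[C@H]1O[C@@H](n2cnc3c(N)ncnc32)[C@H](O)[C@@H]1O` differs from it only there, bearing a tert-butyl group instead; in this assay compound 2 gives 6850 nM. Of the two numbers, compound 2 has the higher, and the step is a 570-fold higher number from compound 1 to compound 2 (2.76 log units; beyond the scatter), so compound 2 is the weaker binder of the pair by a wide margin.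

Compound 3 `Nc1ncnc2c1ncn2[C@@H]1O[C@H](C(=O)NC2CCCC2)[C@@H](O)[C@H]1O` changes the same position once more: cyclopentyl in place of tert-butyl on an amide-type nitrogen. Within the data shown here, no measured step covers a cyclopentyl group directly. Among the measured compounds shown here, the one step that bears on the change, a 570-fold higher number from compound 1 to compound 2 (2.76 log units; beyond the scatter), shows that what sits on this amide nitrogen can move the number by a large amount. A cyclopentyl group is neither the open chain of compound 1 nor the tert-butyl of compound 2, so the expectation is a drop in this assay from compound 2 toward compound 1 without reaching it. Compound 3 is expected at 150 nM, with a range from 20 nM to 1500 nM, which corresponds to an estimated step of a 46-fold lower number from compound 2 to compound 3 (1.66 log units; beyond the scatter).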

Compound 3, inhibition constant: 49 nM
Compound 3: the middle estimate sits 3.1-fold (0.49 log units) above what was measured, within the range that was stated.
By their numbers in this assay, from the lowest: compound 1; then compound 3; then compound 2.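

In this assay, replacing tert-butyl with cyclopentyl gives a 140-fold lower number from compound 2 to compound 3 (2.15 log units; beyond the scatter) and so recovers most of the ground lost in compound 2, which shows that the weak binding of compound 2 does not extend to every group on this amide-type nitrogen other than an open chain. Set against the pentyl group, the same ring gives a 4.1-fold higher number from compound 1 to compound 3 (0.61 log units; beyond the scatter) and this far smaller step is still beyond the scatter, so tying the substituent into a ring costs something, but the cost is modest beside the gap that separates tert-butyl from the other two groups. Nothing available explains why these three groups differ as they do.

As far as these compounds go, how the number depends on ring size remains open, since a cyclobutyl or cyclohexyl group on the same nitrogen could fall on either side of compound 3. Also open, from the compounds shown here alone, is how far the open chain of compound 1 can be changed, for instance by extending it to a hexyl group or by ending it in an amine or a carboxylic acid.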